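Removing the piperidine ring from a purine nucleoside series

This account rests on a few compounds, and the source may have more. Where it says the series, first, only, none or still open, it means among the compounds named here.

Measured compounds:
Compound 1, `CCn1c(=O)n(C2OC(CO)[C@@H](O)[C@H]2O)c2nc(N)nc(O)c21`, gives 82% in a functional assay on the whole organism (B cells) with Mus musculus as the target; on this read-out higher numbers stand for larger maximal responses and lower numbers for smaller maximal responses.
Compound 2, `NCC(O)Cn1c(=O)n(C2OC(CO)[C@@H](O)[C@H]2O)c2nc(N)nc(O)c21`, gives 110% in this assay.
Compound 3, `Nc1nc(O)c2c(n1)n(C1OC(CO)[C@@H](O)[C@H]1O)c(=O)n2CCN1CCCCC1`, gives 0% in this assay.

Compound 3 stands lowest of the three in this assay, with compound 1 nearest (a number 82 percentage points lower from compound 1 to compound 3 (beyond the scatter)) and compound 2 furthest (a number 110 percentage points lower from compound 2 to compound 3 (beyond the scatter)). Compound 4, `CCCCn1c(=O)n(C2OC(CO)[C@@H](O)[C@H]2O)c2nc(N)nc(O)c21`, differs from compound 3 in one place: ethyl in place of piperidin-1-yl on a saturated chain carbon, two bonds along the chain from an aromatic nitrogen. The step from compound 1 to compound 3 bears on this most directly, as it shows a large loss when piperidin-1-yl is introduced at the same place; compound 4 undoes that and carries only a longer alkyl chain, so a large step upward in this assay is expected, roughly reversing that loss: a number 80 percentage points higher from compound 3 to compound 4 (beyond the scatter). For compound 4 the estimated value is 80%, with a range from 45% to 110%.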

Compound 4, largest response reached (reported as maximal response), in percent of the reference or control that the assay uses: 86%
Compound 4: the middle estimate sits 6 percentage points below what was measured, and the stated range covers the measured number.
By their numbers in this assay, from the lowest: compound 3; then compounds 1 and 4 (each within the scatter of the next); then compound 2.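

In this assay, butyl in compound 4 brings the response back, with a number 86 percentage points higher from compound 3 to compound 4 (beyond the scatter), so the loss goes with the piperidin-1-yl group rather than with a longer chain as such. Lengthening the plain alkyl chain leaves the response within the scatter, with a number 4 percentage points higher from compound 1 to compound 4 (within the scatter), while the 2-amino-1-hydroxyethyl compound keeps an edge, with a number 24 percentage points lower from compound 2 to compound 4 (beyond the scatter). Nothing available explains these differences. From the compounds shown here alone, whether a dimethylamino group or a morpholine ring at the end of the same chain would also remove the response stays open.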